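The source may hold more compounds than are shown below. What is called first, only, known or untested is meant among the compounds shown, and "the series" means these compounds.

Values in an ADME assay on liver (Mesocricetus auratus) for metabolic stability, using microsomes; on this read-out lower numbers stand for slow clearance and higher numbers for fast clearance:
- Compound 1 `O=C(Nc1[nH]nc(-c2ccccn2)c1C1CC1)c1ccccc1F`: > 100 mL.min-1.g-1 (a limit, not a number)
- Compound 2 `O=C(NCc1cccc(Cl)c1)Nc1cc(-c2ccccn2)n[nH]1`: 434 mL.min-1.g-1

Compound 1 has no exact reading, only the limit > 100 mL.min-1.g-1. This shows that it is cleared quickly, but not how quickly.

Compound 3 `O=C(NCc1ccccc1)Nc1[nH]nc(-c2ccccn2)c1C1CC1` keeps the core of compound 1 and has benzylamino in place of 2-fluorophenyl on a carbonyl carbon. Going by the values given here, no measured pair shows what this change does, so any forecast is loose. The closest guide is compound 2, which also has a benzylamino-type group on a carbonyl carbon and gives 434 mL.min-1.g-1 in this assay. Clearance is therefore expected to stay fast, with a rise of moderate size over the limit as the expected outcome, a step that the limit leaves unreadable from compound 1 to compound 3. For compound 3 the estimated value is 280 mL.min-1.g-1, with an expected range of 110 mL.min-1.g-1 to 700 mL.min-1.g-1.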

Compound 3, intrinsic clearance in microsomes: > 400 mL.min-1.g-1
Compound 3 gave a limit, no number (the forecaster's own chance of this, stated with the estimate: 20%); middle value at least 1.4-fold (0.15 log units) away from the limit.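

Going by these compounds alone, compound 1 and compound 3 each have only a limit in this assay, and no step between them can be read. The compounds shown leave open how quickly either compound is cleared, and whether benzylamino in place of 2-fluorophenyl on a carbonyl carbon changes clearance at all.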